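The source may report more compounds than this note shows. Statements on the series, on what has been measured and on what is new or still open speak of the compounds shown alone.

Of the compounds shown here, three built on one shared core have been tested in a functional assay on HCT-116 cells (Homo sapiens) for antiproliferative activity, read by MTT assay, with a stated time of 68 h; on this read-out higher numbers stand for weaker inhibition and lower numbers for stronger inhibition. Compound 1 `CCOc1n[nH]c2ncc(C#Cc3c(F)ccc(NS(=O)(=O)c4cccnc4)c3F)cc12` carries an ethoxy group on the core and in this assay compound 1 gives 10000 nM. Compound 2 `Cc1n[nH]c2ncc(C#Cc3c(F)ccc(NS(=O)(=O)c4cccnc4)c3F)cc12` carries a methyl group in that place and gives 4630 nM, so the step of a 2.2-fold lower number from compound 1 to compound 2 (0.33 log units; beyond the scatter) is a modest gain. Compound 3 `O=S(=O)(Nc1ccc(F)c(C#Cc2cnc3[nH]nc(-c4ccncc4)c3c2)c1F)c1cccnc1` carries a pyridin-4-yl group in the same place. For compound 3 this assay reports only a limit, > 10000 nM, which is a boundary of the assay and not a number. Compound 3 therefore stands at the weak end of the three: the step of a number no lower from compound 1 to compound 3 (the limit leaves the size open) cannot be sized, and the step of an at least 2.1-fold higher number from compound 2 to compound 3 (0.33 log units; beyond the scatter) is at least modest, since the value of compound 3 sits at the limit of > 10000 nM in this assay, at which 1 of the 3 values shown sits.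

Compound 4 `O=S(=O)(Nc1ccc(F)c(C#Cc2cnc3[nH]nc(-c4cccc(Cl)c4)c3c2)c1F)c1cccnc1` is the next compound, and it differs from compound 3 by 3-chlorophenyl in place of pyridin-4-yl on an aromatic carbon. Going by the values given here, no measured step involves a 3-chlorophenyl group, so the two nearest steps, the unsized one from compound 1 and the at least modest loss from compound 2 to compound 3, give only a starting point near the limit, without a clear direction. The step of an at least 1.2-fold lower number from compound 3 to compound 4 (0.09 log units; that floor lies within the scatter) is expected to stay close to no change. Compound 4 is estimated at 8000 nM, within a range from 2000 nM to 30000 nM.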

Compound 4, half-maximal inhibitory concentration: > 10000 nM
Compound 4 gave a limit, no number (the forecaster's own chance of this, stated with the estimate: 45%); middle value at least 1.2-fold (0.09 log units) away from the limit.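

In this assay compound 4 gives > 10000 nM, which is a limit of the assay and not a number. Replacing pyridin-4-yl with a ring of carbon only that carries a chlorine therefore still brings no readable number at this position, and methyl keeps its lead over this second aromatic ring, with an at least 2.1-fold higher number from compound 2 to compound 4 (0.33 log units; beyond the scatter). The step of a number no lower from compound 1 to compound 4 (the limit leaves the size open) cannot be sized, the step to compound 4 from compound 3 cannot be read, and the two compounds with an aromatic ring at this position now share one boundary: the limit of > 10000 nM in this assay, at which 2 of the 4 values shown sit.

As far as these compounds go, how far compound 3 and compound 4 actually lie from each other stays open, as does whether the ring nitrogen or the chlorine matters at all for this read-out. Also open, from the compounds shown here alone, is whether an amine, a hydroxyl or a longer chain such as propyl on this aromatic carbon would fall nearer to methyl or nearer to the two ring groups.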